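Replacing allyl with thiophen-2-yl in compound 1

The source may report more compounds than this note shows. Statements on the series, on what has been measured and on what is new or still open speak of the compounds shown alone.

In a functional assay on KB cells (Homo sapiens) for cytotoxicity (on this read-out higher numbers stand for weaker inhibition and lower numbers for stronger inhibition), compound 1 `C=CCOc1ccc2c(c1)C(=O)C=CC2=O` gives 10200 nM and so lies within the scatter of both compound 2 `CS(=O)(=O)OC1=CC(=O)c2ccccc2C1=O` at 7180 nM and compound 3 `Cc1ccc(S(=O)(=O)OC2=CC(=O)c3ccccc3C2=O)cc1` at 18800 nM on this read-out. Compound 4 `O=C1C=CC(=O)c2cc(Oc3cccs3)ccc21` is still unmeasured and carries thiophen-2-yl in place of allyl on an oxygen on an aromatic ring in its structure. Among the compounds with values here, the one measured step that also brings in an aromatic ring is modest, a 2.6-fold higher number from compound 2 to compound 3 (0.42 log units; beyond the scatter) when 4-methylphenyl replaces methyl on a sulfonyl sulfur, but it sits elsewhere and is only a weak guide. A slight rise within the scatter is expected, an estimated 1.3-fold higher number from compound 1 to compound 4 (0.11 log units; within the scatter) in this assay overall. Compound 4 is estimated at 13000 nM with an expected range from 4500 nM to 35000 nM as the likely span.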

Compound 4, half-maximal inhibitory concentration: 18300 nM
For compound 4 the middle estimate is 1.4-fold (0.15 log units) below the measured one, and the stated range covers the measured number.
By their numbers in this assay, from the lowest: compounds 2, 1, 4 and 3 (each within the scatter of the next, the first and the last beyond it).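

Swapping allyl for thiophen-2-yl on an oxygen on an aromatic ring gives a 1.8-fold higher number from compound 1 to compound 4 (0.25 log units; within the scatter) in this assay. Within the data shown here, this is the first direct comparison at this position, and it shows that a five-membered aromatic ring can replace the open allyl chain with no difference beyond the scatter. No available measurement accounts for this result.

With only these two groups shown on this oxygen, it remains open whether a group of another kind, such as an amine, a carboxylic acid or a longer chain, would shift the number beyond the scatter.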